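The source may hold more compounds than are shown below. What is called first, only, known or untested is meant among the compounds shown, and "the series" means these compounds.

Of the compounds shown here, three have been measured so far.
Compound 1, `CNC(=O)CCc1ccncc1-c1ccc2ccccc2c1`, gives 8980 nM in a functional assay on MDA-MB-231 cells (Homo sapiens) for inhibition, read by sulforhodamine B assay, with a stated time of 72 h; a lower number here means a stronger inhibitor of growth, a higher number a weaker inhibitor of growth.
Compound 2, `O=C(O)CCc1ccncc1-c1ccc2ccccc2c1`, gives in this assay only a limit of the assay, > 10000 nM.
Compound 3, `COC(=O)/C=C/c1ccncc1-c1ccc2ccccc2c1`, gives 4710 nM in this assay.

Compound 3 and compound 1 sit within the usual scatter of each other, as a 1.9-fold lower number from compound 1 to compound 3 (0.28 log units; within the scatter) shows, so neither can be called the stronger of the two. Against compound 2 the step of an at least 2.1-fold lower number from compound 2 to compound 3 (0.32 log units; beyond the scatter) is beyond the scatter, though the limit of > 10000 nM in this assay, at which 1 of the 3 values shown sits, means only a limit is available for that comparison. The next step leads to compound 4, `CN1CCN(C(=O)/C=C/c2ccncc2-c2ccc3ccccc3c2)CC1`, and changes the group on the carbonyl carbon: 4-methylpiperazin-1-yl in place of methoxy on a carbonyl carbon. Among the compounds with values here, the only measured step at the same place is an at least 1.1-fold higher number from compound 1 to compound 2 (0.04 log units; that floor lies within the scatter), which lies within the scatter, while an at least 2.1-fold lower number from compound 2 to compound 3 (0.32 log units; beyond the scatter) changes the chain and the carbonyl substituent at once. Within the data shown here, no measured pair swaps methoxy for 4-methylpiperazin-1-yl. A step of no more than the scatter is therefore expected in this assay. Compound 4 is expected to give 4000 nM, between 1500 nM and 12000 nM. The expected step of a 1.2-fold lower number from compound 3 to compound 4 (0.07 log units; within the scatter) is thus small.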

Compound 4, concentration for 50% growth inhibition: > 10000 nM
Compound 4 was reported as a limit (the forecaster's own chance of this, stated with the estimate: 10%); middle value at least 2.5-fold (0.39 log units) away from the limit.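

In this assay, within the data shown here, the group on the carbonyl carbon, whose other neighbour is the double-bonded chain carbon, is the only thing that changes, and an at least 2.1-fold higher number from compound 3 to compound 4 (0.32 log units; beyond the scatter) shows that this position responds to such a swap. Among these compounds, the only earlier swap confined to a carbonyl carbon, an at least 1.1-fold higher number from compound 1 to compound 2 (0.04 log units; that floor lies within the scatter), could not show this, as its floor stays within the scatter. Compound 4 gives only a limit of the assay, > 10000 nM, so the size of its step is a floor and not a measured gap: the limit of > 10000 nM in this assay, at which 2 of the 4 values shown sit.

On these data alone, whether a small amine such as dimethylamino on this carbonyl carbon would behave like 4-methylpiperazin-1-yl remains open. So does whether the outcome follows the ring itself or its second nitrogen, which a piperidin-1-yl or morpholin-4-yl group in the same place could help to separate.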